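The compounds below may be only part of what the source reports. "The series", "measured", "known", "first", "only" and "open" are said of these compounds alone.

In a functional assay on HCT-15 cells (Homo sapiens) for cytotoxicity, read by sulforhodamine B assay, with a stated time of 48 h (a lower number here means that less compound is tolerated, a higher number that more compound is tolerated), compound 1 `ClCc1ccc(Cn2cnc3c(Cl)ncnc32)cc1` gives 63100 nM. Compound 2 `Nc1nc(Cl)c2ncn(Cc3ccc(CCl)cc3)c2n1` gives 67600 nM. Compound 3 `ClCc1ccccc1Cn1cnc2c(Cl)ncnc21` gives 43700 nM.

All three measured values lie within the usual scatter of one another. Compound 1 and compound 2 differ by a single change, (amino in place of hydrogen on an aromatic carbon), and that change produced a 1.1-fold higher number from compound 1 to compound 2 (0.03 log units; within the scatter). Compound 1 and compound 3 share the same atoms joined differently; how their cores differ is not broken down here. Compound 4 `Nc1nc(Cl)c2ncn(Cc3ccccc3CCl)c2n1` has not yet been measured. It stands to compound 3 as compound 2 stands to compound 1, the change being (amino in place of hydrogen on an aromatic carbon), the same change at the same place. The step from compound 3 to compound 4 is therefore expected to be small, about a 1.1-fold higher number from compound 3 to compound 4 (0.03 log units; within the scatter), because the same change earlier gave a 1.1-fold higher number from compound 1 to compound 2 (0.03 log units; within the scatter). Compound 4 is estimated at 47000 nM, most likely lying from 25000 nM to 90000 nM.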

Compound 4, concentration lethal to 50% of the cells: > 100000 nM
Compound 4 gave a limit, no number; the forecaster's own chance of this, stated with the estimate: 5%; middle value at least 2.1-fold (0.32 log units) from the limit.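

Compound 4 gives > 100000 nM in this assay, and this is a limit of the assay, not a number. Amino in place of hydrogen on an aromatic carbon still gave a readable step on this core, an at least 2.2-fold higher number from compound 3 to compound 4 (0.35 log units; beyond the scatter), while on the core of compound 1 the same change gave a 1.1-fold higher number from compound 1 to compound 2 (0.03 log units; within the scatter). This does not show that the change behaves differently on the two cores, and the size of the step on the core of compound 3 stays unknown: the same change on two cores in this assay, a 1.1-fold higher number (0.03 log units; within the scatter) from compound 1 to compound 2 and an at least 2.2-fold higher number (0.35 log units; beyond the scatter) from compound 3 to compound 4; the limit leaves it open whether they differ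

The compounds shown leave open how a methylamino or methoxy group on the same aromatic carbon would read in this assay. They also leave open how either core would read with a hydroxyl group there.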